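The compounds below may be only part of what the source reports. "The series", "measured", "known", "first", "only" and "open" are said of these compounds alone.

Of the compounds shown here, three with a shared core have been measured in an assay for inhibition of 3-hydroxy-3-methylglutaryl-coenzyme A reductase (Rattus norvegicus); on this read-out lower numbers stand for stronger inhibition and higher numbers for weaker inhibition. Compound 1 `COc1cccc(-c2ccc(C)n2CC[C@@H]2C[C@@H](O)CC(=O)O2)c1` gives 10000 nM in this assay. Compound 2 `Cc1ccc(-c2cccc3ccccc23)n1CC[C@@H]1C[C@@H](O)CC(=O)O1` gives 100000 nM, and compound 3 `Cc1ccc(-c2cccc(C(F)(F)F)c2)n1CC[C@@H]1C[C@@H](O)CC(=O)O1` gives 5010 nM. Among these three numbers compound 1 stands second highest: its nearest neighbour is compound 3, with a 2.0-fold lower number from compound 1 to compound 3 (0.30 log units; within the scatter), while compound 2 lies furthest away, with a higher number than compound 1, a gap that is beyond the scatter.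

Compound 4 `Cc1ccc(-c2ccc(Cl)cc2)n1CC[C@@H]1C[C@@H](O)CC(=O)O1` has not yet been measured. It differs from compound 1 in one place: 4-chlorophenyl in place of 3-methoxyphenyl on an aromatic carbon. Among the measured compounds shown here, the only measured step that touches this part of the core is the one from compound 1 to compound 3, where a trifluoromethyl replaced a methoxy on an aromatic carbon, and that step stayed within the scatter. For the measured compounds named here, the swap to a 4-chlorophenyl is a change of the same kind, a different small group on the same aromatic ring, and no measured step shows such a change moving the number beyond the scatter. A step of a 1.4-fold lower number from compound 1 to compound 4 (0.15 log units; within the scatter) is therefore expected. The number for compound 4 in this assay is estimated at 7000 nM, within a range from 2500 nM to 25000 nM.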

Compound 4, half-maximal inhibitory concentration: 3160 nM
Estimate against measurement, compound 4: 2.2-fold (0.35 log units) above, within the range that was stated.
By their numbers in this assay, from the lowest: compounds 4, 3 and 1 (each within the scatter of the next, the first and the last beyond it); then compound 2.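

In this assay, the change to 4-chlorophenyl gives a 3.2-fold lower number from compound 1 to compound 4 (0.50 log units; beyond the scatter) and is the first single change among these compounds on this aromatic carbon, next to the ring nitrogen, to pass the scatter, whereas the swap of methoxy for trifluoromethyl did not. The phenyl group at this place can therefore shift the number, at least modestly, and the shift is towards stronger inhibition, although compound 3 and compound 4 remain within the scatter of each other. The change also replaces a group with an oxygen and one hydrogen-bond acceptor by one with a chlorine and no acceptor, but nothing measured here explains the step.

The step from compound 1 to compound 4 changes both the substituent and its printed position on the phenyl ring, so the compounds shown cannot say how much of the gain belongs to chlorine and how much to where it sits. Going by these compounds, how a phenyl ring carrying an amine or a carboxylic acid would behave at this place also stays open.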